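The source may report more compounds than this note shows. Statements on the series, on what has been measured and on what is new or still open speak of the compounds shown alone.

Compound 1 `Cc1cc(C)c(-c2nc(CN3CCC(C(=O)NCCCN4C[C@H](C)C[C@H](C)C4)CC3)c(C)o2)c(C)c1` was tested in an ADME assay on microsomes from liver (Rattus norvegicus) for metabolic stability, read by LC-MS, using NADPH, at 37 degrees C; a lower number here means that the compound disappears faster, a higher number that the compound lasts longer. In this assay compound 1 reached the limit > 0.5 h, which is a limit of the measurement and not a number, as the evidence the limit of > 0.5 h in this assay, at which 1 of the 2 values shown sits, records. Compound 2 `Cc1ccccc1-c1nc(CN2CCC(C(=O)NCCCN3CC4CCCC(C4)C3)CC2)c(C)o1` is the other measured member; in this assay compound 2 gives 0.123 h. Compound 3 `COc1ccc(-c2nc(CN3CCC(C(=O)NCCCN4C[C@H](C)C[C@H](C)C4)CC3)c(C)o2)cc1OC` is not yet measured and differs from compound 1 by 3,4-dimethoxyphenyl in place of 2,4,6-trimethylphenyl on an aromatic carbon. A modest step downward is expected an at least 1.4-fold lower number from compound 1 to compound 3 (0.15 log units; that floor lies within the scatter), possibly beyond the scatter. The expected half-life of compound 3 in this assay is 0.35 h, with a range from 0.12 h to 1 h.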

Compound 3, half-life: > 0.5 h
Compound 3: no number, only a limit (the forecaster's own chance of this, stated with the estimate: 35%); middle value at least 1.4-fold (0.15 log units) from the limit.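

Compound 1 and compound 3 both rest on a limit in this assay, so no step between them can be read: the limit of > 0.5 h in this assay, at which 2 of the 3 values shown sit.

The compounds shown leave open whether 3,4-dimethoxyphenyl in place of 2,4,6-trimethylphenyl changes the half-life at all.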